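The source may report more compounds than this note shows. Statements on the series, on what has been measured and on what is new or still open speak of the compounds shown alone.

Compound 1 `N=C(N)N/N=C/c1c(-c2ccsc2)nc2sccn12` carries a thiophen-3-yl group on its shared core, and in a functional assay on cells (Cancer cell lines, Homo sapiens) for inhibition (on this read-out lower numbers stand for stronger inhibition of growth and higher numbers for weaker inhibition of growth), compound 1 gives 14800 nM. Compound 2 `Cc1cc(-c2nc3sccn3c2/C=N/NC(=N)N)c(C)s1` differs from it by the change (2,5-dimethylthiophen-3-yl in place of thiophen-3-yl on an aromatic carbon), and in this assay compound 2 gives 13800 nM; the step of a 1.1-fold lower number from compound 1 to compound 2 (0.03 log units; within the scatter) is small. Compound 3 `N=C(N)N/N=C/c1c(-c2ccsc2)nc2n1CCS2` has a different core; how the two cores differ is not broken down here. In this assay compound 3 gives 17400 nM, which sits close to the numbers for compound 1 and compound 2. Compound 4 `Cc1cc(-c2nc3n(c2/C=N/NC(=N)N)CCS3)c(C)s1` is made from compound 3 by the change (2,5-dimethylthiophen-3-yl in place of thiophen-3-yl on an aromatic carbon). Within the data shown here, this is the same kind of change as the one from compound 1 to compound 2, though the place is not the same word for word: here it also lies two ring bonds from two ring atoms that each bear a fused ring. Because the step of a 1.1-fold lower number from compound 1 to compound 2 (0.03 log units; within the scatter) stayed within the scatter, the step from compound 3 to compound 4 is expected to be a 1.1-fold lower number from compound 3 to compound 4 (0.05 log units; within the scatter). Compound 4 is therefore estimated at 15500 nM, expected between 7000 nM and 34000 nM.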

Compound 4, concentration for 50% growth inhibition: 15500 nM
Compound 4: middle estimate and measured number agree at the digits printed, and the stated range covers the measured number.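

In this assay, putting 2,5-dimethylthiophen-3-yl in place of thiophen-3-yl gives a 1.1-fold lower number from compound 3 to compound 4 (0.05 log units; within the scatter), and on these two cores the change behaves alike: the same change on two cores in this assay, a 1.1-fold lower number (0.03 log units; within the scatter) from compound 1 to compound 2 and a 1.1-fold lower number (0.05 log units; within the scatter) from compound 3 to compound 4, 1.0-fold (0.02 log units) apart, within the scatter of two such steps. Across this pair of cores, then, the swap leaves the number about where it was, and a step read on one core served as a fair guide to the step on the other. It does not show that a change with a real effect would carry over in the same way, since both steps are too small to tell from the scatter, and two cores in a single assay say nothing about any other core.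

All four compounds carry either thiophen-3-yl or 2,5-dimethylthiophen-3-yl at this place, which leaves open whether any other group there would move the number beyond the scatter. A phenyl ring, an amine or a carboxylic acid at the same carbon would be a stronger test of whether steps carry from one core to the other.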